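Pyridin-2-yl for 4-chlorophenyl on the shared core

The source may hold more compounds than are shown below. What is called first, only, known or untested is meant among the compounds shown, and "the series" means these compounds.

Going by the values given here, compound 2 `Clc1ccc(-c2cc(-c3ccc(Cl)o3)cc(-c3ccsc3)n2)cc1` gives 5190 nM in a functional assay on HCT-15 cells (Homo sapiens) for cytotoxicity, in the presence of a further agent that is not named here (on this read-out lower numbers stand for stronger inhibition and higher numbers for weaker inhibition), the highest of the two numbers so far; compound 1 `Cc1ccccc1-c1cc(-c2ccc(Cl)o2)cc(-c2ccsc2)n1` gives 4630 nM, and the two lie within the scatter. Among the compounds with values here, the one measured step, a 1.1-fold higher number from compound 1 to compound 2 (0.05 log units; within the scatter), swapped one aryl group for another without effect beyond the scatter. Compound 3 `Clc1ccc(-c2cc(-c3ccsc3)nc(-c3ccccn3)c2)o1` carries pyridin-2-yl in place of 4-chlorophenyl on an aromatic carbon, next to the ring nitrogen. Within the data shown here, no measured step exchanges a carbon-only ring for a nitrogen-containing one here, so the bearing of the single step is indirect. Compound 3 is expected near 5000 nM, with a range of 1500 nM to 16000 nM. The estimated step is a 1.0-fold lower number from compound 2 to compound 3 (0.02 log units; within the scatter), with wide uncertainty.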

Compound 3, half-maximal inhibitory concentration: > 50000 nM
Compound 3 was reported as a limit; the forecaster's own chance of this, stated with the estimate: 10%; middle value at least 10-fold (1.00 log units) away from the limit.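

Compound 3 stands only as a limit: the limit of > 50000 nM in this assay, at which 1 of the 3 values shown sits. In this assay, the change to pyridin-2-yl gives an at least 9.6-fold higher number from compound 2 to compound 3 (0.98 log units; beyond the scatter), and against 2-methylphenyl it gives an at least 10-fold higher number from compound 1 to compound 3 (1.03 log units; beyond the scatter). This position, next to the ring nitrogen, therefore separates the two carbon-only rings, which lie within the scatter of each other, from the ring with a hetero atom.

From the compounds shown here alone, it remains open whether this separation follows from the presence of a ring nitrogen or from where that nitrogen sits, a question that pyridin-3-yl or pyridin-4-yl would address. Going by these compounds, how an aminophenyl or carboxyphenyl group behaves here also remains open.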